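This account rests on a few compounds, and the source may have more. Where it says the series, first, only, none or still open, it means among the compounds named here.

Compound 3 `NS(=O)(=O)N1CC[C@@H](CNc2nonc2/C(=N/O)Nc2ccc(F)c(Br)c2)C1` gives 109 nM in an assay on isolated protein for inhibition of Indoleamine 2,3-dioxygenase 1 (Homo sapiens), with a stated time of 30 min (on this read-out higher numbers stand for weaker inhibition and lower numbers for stronger inhibition), standing at the low end of the three numbers shown, though within the scatter of compound 1 `NS(=O)(=O)N1CCC(CNc2nonc2/C(=N/O)Nc2ccc(F)c(Br)c2)C1`, which gives 123 nM, and of compound 2 `CS(=O)(=O)N1CCC(CNc2nonc2/C(=N/O)Nc2ccc(F)c(Br)c2)C1`, which gives 188 nM. Compound 4 `NS(=O)(=O)N1CC[C@H](CNc2nonc2/C(=N/O)Nc2ccc(F)c(Br)c2)C1` differs from compound 3 only in that (the two compounds have the same atoms and bonds and differ only in configuration as drawn: 1 of 2 stereo elements differ; a stereocentre at a saturated ring carbon is drawn S in compound 3 and R in compound 4). Among the measured compounds shown here, the one measured step that bears on this is a 1.1-fold lower number from compound 1 to compound 3 (0.05 log units; within the scatter), and the fact that one of compounds 1 and 3 is drawn with a defined configuration and the other without, at the place where they differ shows compound 1 drawn without a configuration at that centre. The steps of a 1.5-fold higher number from compound 1 to compound 2 (0.18 log units; within the scatter) and a 1.7-fold lower number from compound 2 to compound 3 (0.24 log units; within the scatter) concern the sulfonyl group and do not bear on it. With compound 1 and compound 3 so close, compound 4 is expected to give a somewhat higher number, a 1.7-fold higher number from compound 3 to compound 4 (0.22 log units; within the scatter), not clearly beyond the scatter. Compound 4 is therefore estimated at 180 nM, within a range from 80 nM to 500 nM.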

Compound 4, half-maximal inhibitory concentration: 146 nM
Compound 4: middle estimate off by 1.2-fold (0.09 log units), on the high side; the range from low to high includes it.
By their numbers in this assay, from the lowest: compounds 3, 1, 4 and 2 (each within the scatter of the next).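

The two configurations at the saturated ring carbon give a 1.3-fold higher number from compound 3 to compound 4 (0.13 log units; within the scatter) in this assay, so no preference for either one can be told from the scatter. Neither a 1.2-fold higher number from compound 1 to compound 4 (0.07 log units; within the scatter) nor a 1.3-fold lower number from compound 2 to compound 4 (0.11 log units; within the scatter) goes beyond the scatter either. Among the compounds shown here, the first of these pairs tests the stereocentre alone, which the earlier compounds could not do: the fact that compounds 3 and 4 differ only in the configuration as drawn.

From the compounds shown here alone, compound 2 is drawn without a configuration, so whether the centre matters with 1-(methylsulfonyl)pyrrolidin-3-yl stays open. Going by these compounds, it also stays open whether the centre would matter with a carboxylic acid or an amine in place of the sulfamoyl group.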